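A few compounds are considered here, and "the series" means these few. Any claim that something is new, unique, unknown or untested is made for them only; others in the source may bear on it.

Compound 3 `CNC(=O)c1cc(C(=O)NC2CC2)cn(Cc2ccc(OC)cc2)c1=O` gives 3 in a physicochemical assay for lipophilicity, at pH 7.4 (on this read-out higher numbers stand for higher lipophilicity and lower numbers for lower lipophilicity), level at the digits shown with compound 2 `CNC(=O)c1cccn(Cc2ccccc2)c1=O`, which gives 3. Compound 1 `CNC(=O)c1cc(C(=O)NC2CCC2)cn(Cc2ccccc2)c1=O` gives 3.8, so compound 3 and compound 2 together stand lowest of the three, and compound 1 lies beyond the scatter above them. Within the data shown here, the one measured step, a number 0.80 log units lower from compound 1 to compound 2 (beyond the scatter), concerns a different place on the shared core and does not bear on the change now in question. Compound 4 `CNC(=O)c1cc(C(=O)NC2CC2)cn(Cc2cccc(C)c2)c1=O` differs from compound 3 by 3-methylphenyl in place of 4-methoxyphenyl on a saturated chain carbon bound to an aromatic nitrogen. Among the measured compounds shown here, no measured pair covers this exchange, so the expectation rests on the change itself. The estimated step is a number 0.50 log units higher from compound 3 to compound 4 (beyond the scatter). Compound 4 is therefore expected to give 3.5 in this assay, within a range from 3.1 to 3.9.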

Compound 4, distribution coefficient: 3.6
Compound 4: middle estimate off by 0.10 log units, on the low side, within the range that was stated.
By their numbers in this assay, from the lowest: compounds 2 and 3 (each within the scatter of the next); then compounds 4 and 1 (each within the scatter of the next).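

In this assay, 3-methylphenyl in place of 4-methoxyphenyl on a saturated chain carbon bound to an aromatic nitrogen gives a number 0.60 log units higher from compound 3 to compound 4 (beyond the scatter), which shows that the read-out responds to a change at this place. This single exchange does not separate the loss of the oxygen from the other differences between the two groups. Nothing available accounts for the step. As far as these compounds go, it remains open how 4-methylphenyl or 3-methoxyphenyl would stand against these two groups, and where an amine or a carboxylic acid at this place would fall.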